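Removing the chloro group from compound 2

A few compounds are considered here, and "the series" means these few. Any claim that something is new, unique, unknown or untested is made for them only; others in the source may bear on it.

Measured in a functional assay on A549 cells (Homo sapiens) for inhibition, read by MTT assay; on this read-out higher numbers stand for weaker inhibition and lower numbers for stronger inhibition:
- compound 1 `CCOC(=O)c1c(NC(=O)CC#N)sc(C(=O)Nc2ccc(Cl)cc2)c1-c1ccccc1`: 600 nM
- compound 2 `N#CCC(=O)Nc1sc(C(=O)Nc2ccc(Cl)cc2)c(-c2ccccc2)c1C#N`: 1400 nM
- compound 3 `CCOC(=O)c1c(N)sc(C(=O)Nc2ccc(Cl)cc2)c1-c1ccccc1`: 230 nM

Of these three, compound 2 has the highest number in this assay, which means the weakest inhibition. Compound 4 `N#CCC(=O)Nc1sc(C(=O)Nc2ccccc2)c(-c2ccccc2)c1C#N` differs from it by hydrogen in place of chloro on an aromatic carbon. Neither measured step touches this place. There is a 2.3-fold higher number from compound 1 to compound 2 (0.37 log units; beyond the scatter), with cyano in place of ethoxycarbonyl, and a 2.6-fold lower number from compound 1 to compound 3 (0.42 log units; beyond the scatter), with hydrogen in place of (cyanomethyl)carbonyl. They guide only the size of the step, and no measurement shows its direction. A modest change is therefore expected, tentatively toward weaker inhibition. The expected change is a 1.3-fold higher number from compound 2 to compound 4 (0.11 log units; within the scatter). Compound 4 is estimated at 1800 nM, with an expected range of 700 nM to 4500 nM.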

Compound 4, half-maximal inhibitory concentration: 7590 nM
Compound 4: the middle estimate sits 4.2-fold (0.62 log units) below what was measured; measured number outside the range, above it.
By their numbers in this assay, from the lowest: compound 3; then compound 1; then compound 2; then compound 4.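

In this assay, for the compounds shown here, going from 4-chlorophenyl to phenyl gives a 5.4-fold higher number from compound 2 to compound 4 (0.73 log units; beyond the scatter), so this is the first measured sign that the chlorine matters: removing it weakens inhibition. This rests on a single pair, and it shows the effect only with the nitrile and the (cyanomethyl)carbonyl group that compound 2 carries. No measurement here explains why removing one atom has this effect. As far as these compounds go, it remains open whether removing the chlorine from compound 1 or compound 3 would shift inhibition in the same way. Also open, from the compounds shown here alone, is how a fluoro, methyl or methoxy group would compare with chloro at this place.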